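This account rests on a few compounds, and the source may have more. Where it says the series, first, only, none or still open, it means among the compounds named here.

Compound 1 `O=C(Nc1cccc(-n2cc(-c3ccncc3)c(-c3ccc(Cl)c(O)c3)n2)c1)Nc1ccc(Cl)c(Cl)c1` gives 1060 nM in a functional assay on MCF7 cells (Homo sapiens) for inhibition, read by sulforhodamine B assay, with a stated time of 48 h (on this read-out higher numbers stand for weaker inhibition of growth and lower numbers for stronger inhibition of growth), the highest of the three numbers in the set. Among the measured compounds shown here, compound 2 `COc1cc(-c2nn(-c3cccc(NC(=O)Nc4ccc(Cl)c(C(F)(F)F)c4)c3)cc2-c2ccncc2)ccc1Cl` gives 919 nM; this and the value of compound 1 lie within the scatter of each other, and no single step links the two structures. For the measured compounds named here, compound 3 `COc1cc(-c2nn(-c3cccc(NC(=O)c4ccccc4)c3)cc2-c2ccncc2)ccc1Cl` gives 335 nM, and the only counted step, a 2.7-fold lower number from compound 2 to compound 3 (0.44 log units; beyond the scatter), concerns the group on the carbonyl carbon rather than the aryl on the urea nitrogen. Compound 4 `O=C(Nc1cccc(-n2cc(-c3ccncc3)c(-c3ccc(Cl)c(O)c3)n2)c1)Nc1cccc(C(F)(F)F)c1` differs from compound 1 by 3-(trifluoromethyl)phenyl in place of 3,4-dichlorophenyl on an amide-type nitrogen. Going by the values given here, no measured step bears directly on this change; the aryl on the amide-type nitrogen is kept in kind, so the step is expected to stay within the scatter, a 1.1-fold higher number from compound 1 to compound 4 (0.05 log units; within the scatter). Compound 4 is therefore estimated at 1200 nM, between 500 nM and 3000 nM.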

Compound 4, concentration for 50% growth inhibition: 1340 nM
Compound 4: middle estimate off by 1.1-fold (0.05 log units), on the low side, and the stated range covers the measured number.
By their numbers in this assay, from the lowest: compound 3; then compounds 2, 1 and 4 (each within the scatter of the next).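

Within this assay the change from 3,4-dichlorophenyl to 3-(trifluoromethyl)phenyl on the amide-type nitrogen gives a 1.3-fold higher number from compound 1 to compound 4 (0.10 log units; within the scatter) and is the first direct reading at this position. These two aryl groups are not told apart on this read-out. No measured evidence bears on this result.

Still open, as far as these compounds go, is whether an aryl group is needed on this nitrogen, or whether a cyclohexyl group or a short alkyl chain would serve there. A morpholine or a carboxylic acid on this aryl ring also remains untested in the compounds shown.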